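The compounds below may be only part of what the source reports. "The series", "measured", "known", "first", "only" and "open" are said of these compounds alone.

Compound 1 `CN1CCN(c2ccc(C3=NN(C(=O)c4ccc(C(F)(F)F)cc4)C(c4ccc(N(C)C)cc4)C3)cc2)CC1` and compound 2 `CN(C)c1ccc(C2CC(c3ccc(-n4ccnc4)cc3)=NN2C(=O)c2cc(Cl)cc(Cl)c2)cc1` share a core and were both tested in a functional assay on MDA-MB-231 cells (Homo sapiens) for inhibition, read by sulforhodamine B assay, tested at 10 uM; a higher number here means more inhibition at the concentration tested (going by the name of the read-out), a lower number less inhibition. In this assay compound 1 gives 55.4%, and compound 2 gives 48.8%, the lower of the two numbers, although its gap to compound 1 lies within the scatter. Compound 3 `CN(C)c1ccc(C2CC(c3ccc(-n4ccnc4)cc3)=NN2C(=O)c2ccc(C(F)(F)F)cc2)cc1` has not yet been measured; it differs from compound 2 by 4-(trifluoromethyl)phenyl in place of 3,5-dichlorophenyl on a carbonyl carbon. Since compound 1 carries the same entering group and gives 55.4%, the expected step in this assay is a number 3.2 percentage points higher from compound 2 to compound 3 (within the scatter), nothing beyond the scatter. Compound 3 is therefore estimated at 52%, with a range from 35% to 68%.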

Compound 3, a percentage reported as inhibition, at one concentration (the size of the read-out at that concentration, not a potency): 17.9%
Beside the measured number, compound 3's estimate is 34.1 percentage points above it; measured number below the stated range.
By their numbers in this assay, from the lowest: compound 3; then compounds 2 and 1 (each within the scatter of the next).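

In this assay, the group on the carbonyl carbon proves not to be neutral: 4-(trifluoromethyl)phenyl in place of 3,5-dichlorophenyl gives a number 30.9 percentage points lower from compound 2 to compound 3 (beyond the scatter). With 4-(trifluoromethyl)phenyl held fixed, 1H-imidazol-1-yl in place of 4-methylpiperazin-1-yl on an aromatic carbon gives a number 37.5 percentage points lower from compound 1 to compound 3 (beyond the scatter). Among these three compounds, the low number appears only where these two groups occur together, so neither change can be read alone. Still open, on these data alone, is how 3,5-dichlorophenyl would read with 4-methylpiperazin-1-yl, or a morpholine with either carbonyl group. Nothing given here explains the drop.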